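This account rests on a few compounds, and the source may have more. Where it says the series, first, only, none or still open, it means among the compounds named here.

Compounds measured in an assay on HEK293 cells for displacement of a labelled ligand from 5-hydroxytryptamine receptor 7 (Rattus norvegicus), with a stated time of 60 min; a higher number here means a weaker inhibitor, a lower number a stronger inhibitor: compound 1 `c1ccc(Cn2cc(-c3ccccc3)c3c2CCNC3)cc1` gives 220 nM; compound 2 `FC(F)(F)c1ccc(-c2cn(Cc3ccccc3)c3c2CNCC3)cc1` gives 167 nM.

Compound 1 holds the highest of the two numbers in this assay; its nearest neighbour is compound 2, with a 1.3-fold lower number from compound 1 to compound 2 (0.12 log units; within the scatter). Compound 3 `Clc1ccc(-c2cn(Cc3ccccc3)c3c2CNCC3)c(Cl)c1` differs from compound 1 by 2,4-dichlorophenyl in place of phenyl on an aromatic carbon. Among the measured compounds shown here, the single comparable step, trifluoromethyl in place of hydrogen on an aromatic carbon, also altered the phenyl that leaves here and stayed within the scatter, so no step beyond the scatter is expected from compound 1 to compound 3 in this assay. Compound 3 is therefore estimated at 180 nM, range 70 nM to 450 nM, meaning an expected 1.2-fold lower number from compound 1 to compound 3 (0.09 log units; within the scatter).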

Compound 3, inhibition constant: 2070 nM
Compound 3: middle estimate off by 12-fold (1.06 log units), on the low side; measured number above the stated range.
By their numbers in this assay, from the lowest: compounds 2 and 1 (each within the scatter of the next); then compound 3.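

In this assay, the aromatic carbon carrying the phenyl proves sensitive to change: 2,4-dichlorophenyl in place of phenyl gives a 9.4-fold higher number from compound 1 to compound 3 (0.97 log units; beyond the scatter). Among the compounds shown here, the earlier trifluoromethyl change on the same phenyl gave only a 1.3-fold lower number from compound 1 to compound 2 (0.12 log units; within the scatter), so a substituted phenyl here is not generally neutral, and this is the first step beyond the scatter. No measurement available here bears on the cause of this step.

Open, from the compounds shown here alone, is whether a single chlorine on the phenyl gives a step of this size. Also open, going by these compounds, is whether methoxy in place of the chlorines behaves the same way.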